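Methoxy on the outer ring and its effect on lipophilicity

The source may hold more compounds than are shown below. What is called first, only, known or untested is meant among the compounds shown, and "the series" means these compounds.

Measured compounds:
- compound 1, `COc1ccc(NC[C@H](O)COc2ccc(N3C[C@H](CNC(C)=O)OC3=O)cc2F)cc1`: 0.95
- compound 2, `CC(=O)NC[C@H]1CN(c2ccc(OC[C@@H](O)CNc3ccccc3)c(F)c2)C(=O)O1`: 1.42
- compound 3, `CC(=O)NC[C@H]1CN(c2ccc(OC[C@@H]3CN(c4ccccc4)C(=O)O3)c(F)c2)C(=O)O1`: 1.78

In a physicochemical assay for lipophilicity, read by HPLC (a lower number here means a more polar compound, a higher number a more lipophilic compound), compound 1 gives 0.95. Compound 2 gives 1.42 in this assay, and compound 3 gives 1.78 there, the highest of the three. The change from compound 2 to compound 1 is methoxy in place of hydrogen on an aromatic carbon, and it brought a number 0.47 log units lower from compound 2 to compound 1 (beyond the scatter). How the core of compound 3 differs from that of compound 2 is not broken down here; compound 3 stands above compound 2 by a gap beyond the scatter.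

Compound 4, `COc1ccc(N2C[C@@H](COc3ccc(N4C[C@H](CNC(C)=O)OC4=O)cc3F)OC2=O)cc1`, has not yet been measured. It differs from compound 3 by methoxy in place of hydrogen on an aromatic carbon, the same change that separates compound 2 from compound 1, made at the same kind of place. Because a number 0.47 log units lower from compound 2 to compound 1 (beyond the scatter) was seen for that change, a step of similar direction and size is expected here, a number 0.38 log units lower from compound 3 to compound 4 (beyond the scatter). Compound 4 is therefore estimated at 1.4, with the range 1.05 to 1.75.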

Compound 4, partition coefficient: 1.91
Estimate against measurement, compound 4: 0.51 log units below; the measured number lies above the stated range.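

In this assay the change from phenyl to 4-methoxyphenyl brought a number 0.47 log units lower from compound 2 to compound 1 (beyond the scatter) on one core but a number 0.13 log units higher from compound 3 to compound 4 (within the scatter) on the other. So the step seen on the core of compound 2 did not carry over to the core of compound 3, and in this series the size of the step on one core was no safe guide to its size on the other. For the compounds shown here, this rests on only two pairs and does not show a general rule for the change, and nothing measured here explains why the two cores part ways.

Going by these compounds, whether an amine or a carboxylic acid in the same place on the outer ring would follow the step to compound 1 or the step to compound 4 stays open. Also open, on these data alone, is how the same methoxy change would read on any third core.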